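The compounds below may be only part of what the source reports. "The series", "measured", "known", "first", "only" and "open" are said of these compounds alone.

In an ADME assay on MDBK cells (Bos taurus) for cytotoxicity (on this read-out lower numbers stand for higher toxicity in this test and higher numbers for lower toxicity in this test), compound 1 (`Fc1ccc(Cn2ccc3nc(-c4ccccc4)nc-3c2)cc1`) gives > 100000 nM as a limit of the assay. Compound 2 (`Clc1ccc(Cn2ccc3nc(-c4ccccc4)nc-3c2)cc1`) gives > 100000 nM as a limit too. Within the data shown here, compound 3 (`Brc1ccc(Cn2ccc3nc(-c4ccccc4)nc-3c2)cc1`) gives 83000 nM as the only actual number in the set. The set thus holds the limit of > 100000 nM in this assay, at which 2 of the 3 values shown sit, and that single number. Compound 4 (`N#Cc1ccccc1Cn1ccc2nc(-c3ccccc3)nc-2c1`) has not yet been measured. It carries 2-cyanophenyl in place of the 4-bromophenyl of compound 3 on a saturated chain carbon bound to an aromatic nitrogen (2-cyanophenyl in place of 4-bromophenyl on a saturated chain carbon bound to an aromatic nitrogen). The measured steps are a step that the two limits leave unreadable from compound 1 to compound 2 together with an at least 1.2-fold lower number from compound 1 to compound 3 (0.08 log units; that floor lies within the scatter) and an at least 1.2-fold lower number from compound 2 to compound 3 (0.08 log units; that floor lies within the scatter) as well. All three exchange one halogen for another, and neither readable floor goes beyond the scatter. Among the measured compounds shown here, none brings in 2-cyanophenyl, and no measured step gives a size for this change. With compound 3 at 83000 nM and steps this small, no step beyond the scatter is expected in this assay and no direction is favoured. The expected change is a 1.1-fold higher number from compound 3 to compound 4 (0.04 log units; within the scatter) on this reading. Compound 4 is expected at 90000 nM within an estimated range from 40000 nM to 120000 nM on this read-out.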

Compound 4, half-maximal cytotoxic concentration: > 100000 nM
Compound 4 gave a limit, no number (the forecaster's own chance of this, stated with the estimate: 55%); middle value at least 1.1-fold (0.04 log units) away from the limit.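

In this assay, 2-cyanophenyl in place of 4-bromophenyl on a saturated chain carbon bound to an aromatic nitrogen gives an at least 1.2-fold higher number from compound 3 to compound 4 (0.08 log units; that floor lies within the scatter). Among these compounds, this is the first change in the set that is not a halogen exchange, and with a nitrile on the phenyl ring, compound 4 still gives only a limit of the assay, not a number: the limit of > 100000 nM in this assay, at which 3 of the 4 values shown sit. The steps from compound 1 and from compound 2 to compound 4 join two limits and cannot be read.

Going by these compounds, the actual numbers behind the limits of compound 1, compound 2 and compound 4 remain open, as does whether the nitrile itself or its place on the ring counts more, since 2-cyanophenyl changes both at once. Also open, on these data alone, is what an amine or a carboxylic acid on the phenyl ring, or a longer chain to the aromatic nitrogen, would give in this assay.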